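The source may report more compounds than this note shows. Statements on the series, on what has been measured and on what is new or still open speak of the compounds shown alone.

Series notes. Compound 1 `COc1ccc2c(c1)C(=O)CCN2c1nc(Cl)nc2ccccc12` and compound 2 `COc1ccc2c(c1)C(=O)CCN2c1nc(C)nc2ccccc12` share one core; compound 3 `COc1ccc2c(c1)CCCN(c1nc(Cl)nc3ccccc13)C2` and compound 4 `COc1ccc2c(c1)CCCN(c1nc(C)nc3ccccc13)C2` share another, and the difference between the two cores is not broken down here. In a functional assay on KB cells (Homo sapiens) for cytotoxicity, read by sulforhodamine B assay (on this read-out lower numbers stand for stronger inhibition of growth and higher numbers for weaker inhibition of growth), compound 1 gives 28 nM, compound 2 gives 19 nM and compound 3 gives 11300 nM, a much higher number than either of the first two. Within the first core the change methyl in place of chloro on an aromatic carbon brought a 1.5-fold lower number from compound 1 to compound 2 (0.17 log units; within the scatter). The same change, (methyl in place of chloro on an aromatic carbon), at the same place, leads from compound 3 to compound 4, which has not yet been measured in this assay. Because the earlier step was a 1.5-fold lower number from compound 1 to compound 2 (0.17 log units; within the scatter), the new step is expected to be similarly small, a 1.5-fold lower number from compound 3 to compound 4 (0.18 log units; within the scatter). The estimate for compound 4 in this assay is 7500 nM, expected to fall between 3000 nM and 20000 nM.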

Compound 4, concentration for 50% growth inhibition: 19600 nM
For compound 4 the middle estimate is 2.6-fold (0.42 log units) below the measured one; the measured number falls inside the stated range.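

In this assay, methyl in place of chloro on an aromatic carbon gives a 1.7-fold higher number from compound 3 to compound 4 (0.24 log units; within the scatter). Set beside the earlier step, the change carries over with no difference that can be read: the same change on two cores in this assay, a 1.5-fold lower number (0.17 log units; within the scatter) from compound 1 to compound 2 and a 1.7-fold higher number (0.24 log units; within the scatter) from compound 3 to compound 4, 2.6-fold (0.41 log units) apart, within the scatter of two such steps. On these two cores the change stays small in both cases, but neither step lies beyond the scatter, so no direction can be assigned to it, and two cores give no rule for the wider series.

The compounds shown leave open whether an amine or a longer chain on this aromatic carbon, between two ring nitrogen atoms, would give a step beyond the scatter. They also leave open whether such a step would carry from one core to the other.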